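This account rests on a few compounds, and the source may have more. Where it says the series, first, only, none or still open, it means among the compounds named here.

Of the compounds shown here, three sharing one core have been tested in an ADME assay on MIA PaCa-2 cells (Homo sapiens) for cytotoxicity, read by MTT assay, with a stated time of 72 h; on this read-out higher numbers stand for weaker inhibition and lower numbers for stronger inhibition. Compound 1 `COc1ccc(C2=C(c3cc(OC)c(OC)c(OC)c3)C(=O)CC2O[SiH2]C(C)(C)C)cc1OC` returns only a limit of the assay in this assay, namely > 100 ug/mL. Compound 2 `COc1ccc(C2=C(c3cc(OC)c(OC)c(OC)c3)CC(O[SiH2]C(C)(C)C)C2=O)cc1[N+](=O)[O-]` likewise returns a limit in this assay, > 100 ug/mL. Compound 3 `COc1ccc(C2=C(c3cc(OC)c(OC)c(OC)c3)C(=O)CC2O)cc1` also stands at a limit in this assay, > 100 ug/mL. So compound 3 sits exactly where everything measured here sits: the limit of > 100 ug/mL in this assay, at which 3 of the 3 values shown sit. Within the data shown here, no measured number separates any of these three compounds from another, and no pair of measured compounds differs in just one place, so there is no measured step to build on.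

Compound 4 `CCOC(=O)COc1ccc(C2=C(c3cc(OC)c(OC)c(OC)c3)C(=O)CC2O)cc1` is not yet measured. It differs from compound 3 by ethoxycarbonyl in place of hydrogen on a saturated chain carbon bound to an oxygen on an aromatic ring. Because all three measured compounds rest at the limit of > 100 ug/mL in this assay, at which 3 of the 3 values shown sit, the plain expectation is that compound 4 also gives no number in this assay. The expected step is a step that the limit leaves unreadable from compound 3 to compound 4, none beyond the usual scatter. Compound 4 is estimated at 150 ug/mL in this assay, within 50 ug/mL to 400 ug/mL, most likely reported once more as a limit.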

Compound 4, half-maximal inhibitory concentration: > 100 ug/mL
Compound 4 ended at the assay's limit; the forecaster's own chance of this, stated with the estimate: 80%; the middle value is on the limit's open side.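

Among these compounds, compound 3 and compound 4 both give only a limit in this assay, not a number, so no step between them can be read: the limit of > 100 ug/mL in this assay, at which 4 of the 4 values shown sit. Going by these compounds, whether any compound on the shared core gives an actual number in this assay stays open, as does what ethoxycarbonyl in place of hydrogen does on its own.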